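The compounds below may be only part of what the source reports. "The series", "measured", "known", "first", "only" and "open" are said of these compounds alone.

Compound 2 `COc1ccc2c(c1)c(/C=N\NC(=O)c1c[nH]c3ccccc13)cn2Cc1ccc(Cl)cc1` gives only a limit in a functional assay on LNCaP cells (Homo sapiens) for cytotoxicity (a lower number here means a stronger inhibitor, a higher number a weaker inhibitor), namely > 100000 nM. Compound 1 `COc1ccc(Cn2cc(/C=N\NC(=O)c3c[nH]c4ccccc34)c3cc(OC)ccc32)cc1` likewise gives a limit in this assay, > 100000 nM. The step that the two limits leave unreadable from compound 1 to compound 2 is therefore unreadable, since both values sit at the limit of > 100000 nM in this assay, at which 2 of the 2 values shown sit. Compound 3 `O=C(N/N=C\c1cn(Cc2ccc(Cl)cc2)c2ccc(Br)cc12)c1c[nH]c2ccccc12` differs from compound 2 by bromo in place of methoxy on an aromatic carbon. No measured step reads on this change, and the only comparison shown ends in two limits. Compound 3 is thus expected to give about 150000 nM in this assay, within 30000 nM to 1000000 nM, most likely again as a limit. The implied step that the limit leaves unreadable from compound 2 to compound 3 is expected to be none beyond the scatter.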

Compound 3, half-maximal inhibitory concentration: 3700 nM
Estimate against measurement, compound 3: 41-fold (1.61 log units) above; the measured number lies below the stated range.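

In this assay, for the compounds shown here, bromo in place of methoxy on this aromatic carbon produces an at least 27-fold lower number from compound 2 to compound 3 (1.43 log units; beyond the scatter) and yields the first reading that is a number rather than a limit. This position can therefore change the read-out, which the earlier pair could not show, since the step for chloro in place of methoxy at another place cannot be read. Compound 1 and compound 2 both stay at a limit of the assay: the limit of > 100000 nM in this assay, at which 2 of the 3 values shown sit.

On these data alone, whether this result extends to any other group at this position remains open, for instance an amine or a carboxylic acid. As far as these compounds go, it is also open whether bromo would act alike with the methoxy of compound 1 in place of the chloro of compound 3.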